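A few compounds are considered here, and "the series" means these few. Any claim that something is new, unique, unknown or untested is made for them only; others in the source may bear on it.

In an ADME assay on a cell-free system (plasma, Homo sapiens) for metabolic stability, read by LC-MS (on this read-out lower numbers stand for a shorter-lived compound and higher numbers for a longer-lived compound), compound 1 `NCc1ccc(C(=O)Nc2ccncc2F)cc1-c1cccc(C(=O)OCC2CC2)c1` gives 0.3 h and compound 2 `CCCOC(=O)c1cccc(-c2cc(C(=O)Nc3ccncc3F)ccc2CN)c1` gives 0.317 h and so stands level with it within the scatter. Compound 3 `NCc1ccc(C(=O)Nc2ccncc2F)cc1-c1cccc(C(=O)O)c1` carries hydrogen in place of propyl on an oxygen next to a carbonyl group. For the measured compounds named here, the only measured step (a 1.1-fold higher number from compound 1 to compound 2 (0.02 log units; within the scatter)) exchanges ethyl for cyclopropyl, keeps a chain on that oxygen, and sets no size for this change. On the structural change alone, a large rise in this assay is expected, with wide uncertainty (a 38-fold higher number from compound 2 to compound 3 (1.58 log units; beyond the scatter)). Compound 3 is estimated at 12 h with an expected range of 2 h to 60 h for this read-out.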

Compound 3, half-life: > 2 h
Compound 3: only a limit was reported (the forecaster's own chance of this, stated with the estimate: 40%); the middle value is on the limit's open side.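

In this assay compound 3 gives > 2 h, which is a limit and not a number. Hydrogen in place of the chain on an oxygen next to a carbonyl group moves the read-out beyond the scatter, both against propyl, an at least 6.3-fold higher number from compound 2 to compound 3 (0.79 log units; beyond the scatter), and against cyclopropylmethyl, an at least 6.6-fold higher number from compound 1 to compound 3 (0.82 log units; beyond the scatter). Exchanging one chain for the other stays within the scatter, a 1.1-fold higher number from compound 1 to compound 2 (0.02 log units; within the scatter), so at this position the clear difference lies between carboxy and the two esters shown.

As far as these compounds go, the full size of both new steps remains open. Also open, from the compounds shown here alone, is how a primary amide in place of the carboxy group, or a longer chain on that oxygen, would read in this assay.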